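The source may report more compounds than this note shows. Statements on the series, on what has been measured and on what is new or still open speak of the compounds shown alone.

Working notes on the series. In a functional assay on MIA PaCa-2 cells (Homo sapiens) for antiproliferative activity, read by MTT assay, with a stated time of 3 days (a lower number here means a stronger inhibitor, a higher number a weaker inhibitor), compound 1 `Cc1ccc(C#Cc2cn(C/C=C\CN3C(=O)c4ccccc4C3=O)c(=O)[nH]c2=O)cc1` gives > 100000 nM as its reading, which is a limit of the assay and not a number. In this assay, going by the values given here, compound 2 `CCCCCc1ccc(C#Cc2cn(C/C=C/CN3C(=O)c4ccccc4C3=O)c(=O)[nH]c2=O)cc1` gives 26000 nM as the only true number so far. Compound 3 `O=C1c2ccccc2C(=O)N1C/C=C\Cn1cc(C#CCCc2ccccc2)c(=O)[nH]c1=O` is still unmeasured and carries phenethyl in place of 4-methylphenyl on a triple-bonded carbon on the core of compound 1, with phenethyl in place of 4-methylphenyl on a triple-bonded carbon. Among the compounds with values here, no measured step covers this change, so the expectation is loose. Even compound 2 at 26000 nM is weak, which gives no ground for expecting a large gain. The expected change, an at least 1.2-fold lower number from compound 1 to compound 3 (0.09 log units; that floor lies within the scatter), is small and toward slightly stronger inhibition, and a second limit reading is quite possible. Compound 3 is estimated at 80000 nM, with an expected range from 25000 nM to 250000 nM.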

Compound 3, half-maximal inhibitory concentration: > 100000 nM
Compound 3 was reported as a limit; the forecaster's own chance of this, stated with the estimate: 50%; at least 1.2-fold (0.09 log units) between middle value and limit.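

In this assay compound 3 gives > 100000 nM, which is a limit of the assay and not a number. Compound 1 also stands at a limit, so no step can be read between compound 1 and compound 3: the limit of > 100000 nM in this assay, at which 2 of the 3 values shown sit.

The compounds shown leave open whether phenethyl in place of 4-methylphenyl on a triple-bonded carbon changes inhibition at all.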